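Para Substituents on the Phenyl of Compound 3

The source may report more compounds than this note shows. Statements on the series, on what has been measured and on what is new or still open speak of the compounds shown alone.

Three compounds share one core. Compound 1 `O=C1c2ccc(F)cc2C(=O)N1c1nc(-c2ccccc2)cs1` gives 40200 nM in a functional assay on PC-3 cells (Homo sapiens) for antiproliferative activity, read by MTT assay, with a stated time of 48 h; on this read-out higher numbers stand for weaker inhibition and lower numbers for stronger inhibition. Compound 2 `O=C1c2ccc(F)cc2C(=O)N1c1nc(-c2ccc(Cl)cc2)cs1` gives 38000 nM in this assay, and compound 3 `Cc1ccc(-c2csc(N3C(=O)c4ccc(F)cc4C3=O)n2)cc1` gives 44400 nM in this assay. Compound 3 shows the highest of the three numbers, but its nearest neighbour is compound 1 and its furthest is compound 2, and both gaps sit inside the scatter.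

Compound 4 `O=C1c2ccc(F)cc2C(=O)N1c1nc(-c2ccc([N+](=O)[O-])cc2)cs1` differs from compound 3 by nitro in place of methyl on an aromatic carbon. Going by the values given here, the steps that bear on this site are a 1.1-fold lower number from compound 1 to compound 2 (0.02 log units; within the scatter), a 1.1-fold higher number from compound 1 to compound 3 (0.04 log units; within the scatter) and a 1.2-fold higher number from compound 2 to compound 3 (0.07 log units; within the scatter); each of them stays within the scatter, so the three substituents tried there have not moved the number in this assay one way or the other. Nitro has not been tried, and the data give no ground for a direction.

Compound 4 is therefore expected to give about 40000 nM in this assay, the range running from 15000 nM to 100000 nM. The step expected from compound 3 to compound 4 is a 1.1-fold lower number from compound 3 to compound 4 (0.05 log units; within the scatter), that is, none beyond the scatter.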

Compound 4, half-maximal inhibitory concentration: 39900 nM
Compound 4: middle estimate off by 1.0-fold (0.00 log units), on the high side, within the range that was stated.
By their numbers in this assay, from the lowest: compounds 2, 4, 1 and 3 (each within the scatter of the next).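

With nitro, a group of three heavy atoms with two hydrogen-bond acceptors, on the aromatic carbon para to a large group, this assay still shows no movement: the steps are a 1.1-fold lower number from compound 3 to compound 4 (0.05 log units; within the scatter), a 1.1-fold higher number from compound 2 to compound 4 (0.02 log units; within the scatter) and a 1.0-fold lower number from compound 1 to compound 4 (0.00 log units; within the scatter). The insensitivity seen with chloro and methyl at this position therefore extends to a larger group, and hydrogen, chloro, methyl and nitro cannot be told apart in this read-out. No measurement at hand explains this flat result.

On these data alone, whether an amine, a carboxylic acid or a longer chain at this position would shift the number remains open. Also open, as far as these compounds go, is whether a change to the shared core, rather than to this position, would move the number in this assay.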